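The source may hold more compounds than are shown below. What is called first, only, known or untested is meant among the compounds shown, and "the series" means these compounds.

Working notes on the series. For the measured compounds named here, in an ADME assay on MT4 cells (Homo sapiens) for cytotoxicity, read by MTT assay (on this read-out higher numbers stand for lower toxicity in this test and lower numbers for higher toxicity in this test), compound 1 `O=C1c2ccccc2C(=O)N1CCOC(=S)N(C(=O)c1cc(F)ccc1F)c1ccc(Cl)cc1` gives 54000 nM, the second highest of the three numbers so far. Compound 2 `Cc1ccc(N(C(=O)c2cc(F)ccc2F)C(=S)OCCN2C(=O)c3ccccc3C2=O)cc1` gives 62000 nM, and compound 3 `Cc1ccc(N(C(=O)c2c(Cl)cccc2Cl)C(=S)OCCN2C(=O)c3ccccc3C2=O)cc1` gives 22000 nM. The step of a 1.1-fold higher number from compound 1 to compound 2 (0.06 log units; within the scatter) stays within the scatter, whereas a 2.8-fold lower number from compound 2 to compound 3 (0.45 log units; beyond the scatter) goes beyond it. Compound 4 `O=C1c2ccccc2C(=O)N1CCOC(=S)N(C(=O)c1cccc2ccccc12)c1ccc(Cl)cc1` differs from compound 1 only at the carbonyl carbon: naphthalen-1-yl in place of 2,5-difluorophenyl on a carbonyl carbon. Going by the values given here, the one measured step that alters the group on the carbonyl carbon is a 2.8-fold lower number from compound 2 to compound 3 (0.45 log units; beyond the scatter); no measured step puts a naphthalen-1-yl there. For compound 4 a step of similar direction and size is expected, a lower number beyond the scatter. Compound 4 is estimated at 25000 nM, range 10000 nM to 60000 nM, which means an expected step of a 2.2-fold lower number from compound 1 to compound 4 (0.33 log units; beyond the scatter).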

Compound 4, half-maximal cytotoxic concentration: 6000 nM
Compound 4: middle estimate off by 4.2-fold (0.62 log units), on the high side; measured number below the stated range.
By their numbers in this assay, from the lowest: compound 4; then compound 3; then compounds 1 and 2 (each within the scatter of the next).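

In this assay, naphthalen-1-yl on the carbonyl carbon gives a change beyond the scatter: a 9.0-fold lower number from compound 1 to compound 4 (0.95 log units; beyond the scatter). Compound 3 showed a lower number with 2,6-dichlorophenyl at this place, and compound 4 shows that a group of carbon only can also lower it, so halogen on this group is not required. Nothing available explains the step. Still open, on these data alone, is whether an unsubstituted phenyl or a naphthalen-2-yl on the carbonyl carbon would lower the number as well. Also open, as far as these compounds go, is whether naphthalen-1-yl has the same effect with methyl in place of chloro, as in compound 2.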